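Cytotoxicity limits across a sulfonyl ethyl-to-trifluoromethyl pair

The source may hold more compounds than are shown below. What is called first, only, known or untested is meant among the compounds shown, and "the series" means these compounds.

Compound 1 `CCS(=O)(=O)Nc1ccc(NC(=O)c2ccc(C#N)cc2)cc1C` and compound 2 `Cc1cc(NC(=O)c2ccc(C#N)cc2)ccc1NS(=O)(=O)C(F)(F)F` form one pair, compound 3 `CCS(=O)(=O)Nc1ccc(NC(=O)c2ccc(Cl)cc2)cc1OC` and the unmeasured compound 4 `COc1cc(NC(=O)c2ccc(Cl)cc2)ccc1NS(=O)(=O)C(F)(F)F` the other. In an ADME assay on HEK293 cells (Homo sapiens) for cytotoxicity, read by MTT assay, with a stated time of 48 h (a higher number here means a weaker inhibitor, a lower number a stronger inhibitor), compound 1 gives only a limit of the assay, > 250000 nM. Compound 2 likewise gives only a limit, > 250000 nM. The step that the two limits leave unreadable from compound 1 to compound 2 is therefore not readable; the change is trifluoromethyl in place of ethyl on a sulfonyl sulfur. Compound 3 also returns only a limit, > 250000 nM. The difference between the core of compound 3 and that of compound 1 is not broken down here. Compound 4 carries the same change, (trifluoromethyl in place of ethyl on a sulfonyl sulfur), in the same place. All three values sit at the limit of > 250000 nM in this assay, at which 3 of the 3 values shown sit, so no number anchors the step. Compound 4 is expected to sit at the limit as well, with the step that the limit leaves unreadable from compound 3 to compound 4 read as an estimate only. The estimate for compound 4 is 300000 nM, between 150000 nM and 1000000 nM.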

Compound 4, half-maximal inhibitory concentration: > 250000 nM
Compound 4: a limit, no number; the forecaster's own chance of this, stated with the estimate: 85%; the middle value lies beyond the limit too.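

Compound 3 and compound 4 both return only a limit, so no step between them can be read: the limit of > 250000 nM in this assay, at which 4 of the 4 values shown sit.

In this assay the compounds shown leave open whether trifluoromethyl in place of ethyl on a sulfonyl sulfur changes the read-out at all.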